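Amide nitrogen substituent: sulfamoylphenyl replaced by benzyl

The compounds below may be only part of what the source reports. "The series", "measured", "known", "first", "only" and "open" are said of these compounds alone.

The series keeps one shared core and varies only the group on the amide-type nitrogen. Compound 1 `CCCNC(=O)c1cccc2nc(OCC)n(Cc3ccc(-c4ccccc4-c4nnn[nH]4)cc3)c12` carries propyl there, and in an assay on isolated protein for inhibition of NEDD8-activating enzyme E1 regulatory subunit (Homo sapiens), read by Western blot, with stated times of 10 min and 30 min, tested at 25 uM (a higher number here means more inhibition at the concentration tested (going by the name of the read-out), a lower number less inhibition), compound 1 gives 32.6%. Compound 2 `CCOc1nc2cccc(C(=O)N[C@H]3CC[C@H](C(=O)OC)CC3)c2n1Cc1ccc(-c2ccccc2-c2nnn[nH]2)cc1` carries 4-(methoxycarbonyl)cyclohexyl, and in this assay compound 2 gives 28.6%, the difference being a number 4 percentage points lower from compound 1 to compound 2 (within the scatter). Compound 3 `CCOc1nc2cccc(C(=O)Nc3ccc(S(N)(=O)=O)cc3)c2n1Cc1ccc(-c2ccccc2-c2nnn[nH]2)cc1` carries 4-sulfamoylphenyl, and in this assay compound 3 gives 60.9%, the highest of the three numbers; both steps toward it lie beyond the scatter, a number 28.3 percentage points higher from compound 1 to compound 3 (beyond the scatter) and a number 32.3 percentage points higher from compound 2 to compound 3 (beyond the scatter).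

Compound 4 `CCOc1nc2cccc(C(=O)NCc3ccccc3)c2n1Cc1ccc(-c2ccccc2-c2nnn[nH]2)cc1` is not yet measured. Its change from compound 3 is benzyl in place of 4-sulfamoylphenyl on an amide-type nitrogen. The two steps that bear on it are the ones in which 4-sulfamoylphenyl entered on the amide-type nitrogen, from propyl and from the cyclohexyl ester, and both raised the number beyond the scatter. Here the same group leaves, and benzyl, with no hydrogen-bond donor or acceptor, enters. A drop beyond the scatter is therefore expected, back toward the region occupied by compound 1 and compound 2. Compound 4 is expected to give 35% in this assay, with a range of 15% to 55%. The expected step is a number 25.9 percentage points lower from compound 3 to compound 4 (beyond the scatter).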

Compound 4, a percentage reported as inhibition, at one concentration (the size of the read-out at that concentration, not a potency): 48.9%
Compound 4: middle estimate off by 13.9 percentage points, on the low side; the measured number falls inside the stated range.
By their numbers in this assay, from the lowest: compounds 2 and 1 (each within the scatter of the next); then compound 4; then compound 3.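

In this assay, removing 4-sulfamoylphenyl does not return the number to the level of the two earlier compounds: the change gives a number 12 percentage points lower from compound 3 to compound 4 (beyond the scatter) and leaves benzyl clearly above both, with a number 16.3 percentage points higher from compound 1 to compound 4 (beyond the scatter) and a number 20.3 percentage points higher from compound 2 to compound 4 (beyond the scatter) on the same read-out. Among these four compounds, the two groups with a six-membered aromatic ring of carbon only give the higher numbers, so the gain at this amide-type nitrogen does not depend on the sulfamoyl part alone, since benzyl has 0 hydrogen-bond donors and 0 hydrogen-bond acceptors, although compound 3 still stays above compound 4 beyond the scatter. No supporting data bear on why these groups differ.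

Compound 3 and compound 4 differ both in the sulfamoyl part and in the carbon that benzyl places on the nitrogen, so the share of each in the step stays unresolved. Plain phenyl on the amide-type nitrogen and 4-sulfamoylbenzyl would separate the two, and a carboxylic acid on the ring would test whether another group there matches the sulfamoyl.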